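The source may hold more compounds than are shown below. What is called first, only, known or untested is meant among the compounds shown, and "the series" means these compounds.

In a functional assay on SHEP cells (Homo sapiens) for antiproliferative activity, read by spectrophotometry and resazurin assay, with a stated time of 72 h (a lower number here means a stronger inhibitor, a higher number a weaker inhibitor), compound 1 (`CC(=O)CC1Oc2cc(O)ccc2C=C1c1ccc(O)cc1`) reads 124000 nM and compound 2 (`CC(C)CC(=O)CC1Oc2cc(O)ccc2C=C1c1ccc(O)cc1`) reads 139000 nM while compound 3 (`O=C(CC1Oc2cc(O)ccc2C=C1c1ccc(O)cc1)c1ccc(Br)cc1`) has the lowest number of the three (33000 nM). Compound 4 (`O=C(CC1Oc2cc(O)ccc2C=C1c1ccc(O)cc1)c1ccc(Cl)cc1`) differs from compound 3 at a single spot (chloro in place of bromo on an aromatic carbon): chloro in place of bromo on an aromatic carbon, para to a large group. Among the measured compounds shown here, no measured step makes this exchange. The nearest guides are the modest steps that brought in 4-bromophenyl (a 3.8-fold lower number from compound 1 to compound 3 (0.57 log units; beyond the scatter)) and (a 4.2-fold lower number from compound 2 to compound 3 (0.62 log units; beyond the scatter)), and each replaced a whole group rather than one atom. The other step stayed within the scatter (a 1.1-fold higher number from compound 1 to compound 2 (0.05 log units; within the scatter)). In this assay no step beyond the scatter is therefore expected, and the estimated change is small (a 1.2-fold higher number from compound 3 to compound 4 (0.06 log units; within the scatter)). Compound 4 is expected at 38000 nM (estimated range 20000 nM to 70000 nM).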

Compound 4, half-maximal inhibitory concentration: 167000 nM
Beside the measured number, compound 4's estimate is 4.4-fold (0.64 log units) below it; the measured number lies above the stated range.
By their numbers in this assay, from the lowest: compound 3; then compounds 1, 2 and 4 (each within the scatter of the next).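

Swapping one halogen on the aromatic carbon is enough to change the reading (a 5.1-fold higher number from compound 3 to compound 4 (0.70 log units; beyond the scatter)), a modest step even though only one atom differs. The advantage of 4-bromophenyl therefore does not extend to 4-chlorophenyl, which reads level with the isobutyl and methyl groups on the carbonyl carbon (a 1.2-fold higher number from compound 2 to compound 4 (0.08 log units; within the scatter) and a 1.3-fold higher number from compound 1 to compound 4 (0.13 log units; within the scatter)). Nothing available explains why bromo and chloro differ here.

Going by these compounds, whether bromo is a special case remains open: iodo, fluoro or methoxy at the same place could show whether any other group matches it.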